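Replacing a cyclopropyl-bearing side chain with a methoxy-bearing one

This account rests on a few compounds, and the source may have more. Where it says the series, first, only, none or still open, it means among the compounds named here.

Of the compounds shown here, three sharing one core have been measured in a functional assay on a cell-free system (plasma, Homo sapiens), with a stated time of 3 min; on this read-out lower numbers stand for stronger inhibition and higher numbers for weaker inhibition. Compound 1, `CC1(C[C@@H](O)C(=O)N2C[C@H]3C[C@H]3[C@H]2C(=O)NCc2cc(Cl)ccc2-n2cnnn2)CC1`, gives 500 nM. Compound 2, `CC(C)(C)C[C@@H](O)C(=O)N1CC[C@@H]2C[C@@]21C(=O)NCc1cc(Cl)ccc1-n1cnnn1`, gives 620 nM, and compound 3, `CC(C)(C)OC[C@@H](O)C(=O)N1N=CC[C@H]1C(=O)NCc1cc(Cl)ccc1-n1cnnn1`, gives 750 nM. Compound 1 thus has the lowest of the three numbers, but both other compounds lie within the usual scatter of it, so no order among the three can be read from these values.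

Compound 4, `COC(C)(C)[C@@H](O)C(=O)N1C[C@H]2C[C@H]2[C@H]1C(=O)NCc1cc(Cl)ccc1-n1cnnn1`, is not yet measured. It differs from compound 1 in one place: 1-methoxy-1-methylethyl in place of (1-methylcyclopropyl)methyl on a saturated chain carbon bound to a carbonyl carbon and an oxygen on a saturated carbon. Going by the values given here, no pair of measured compounds differs in a single place, so the size of such a step has not been seen here. The three measured side chains all give numbers within the scatter of one another, which suggests that this part of the molecule tolerates variation. The expected outcome is therefore no step beyond the scatter, giving an estimated 1.2-fold higher number from compound 1 to compound 4 (0.08 log units; within the scatter) in this assay. Compound 4 is estimated to give 600 nM, with a range from 250 nM to 1500 nM.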

Compound 4, half-maximal inhibitory concentration: 1000 nM
Compound 4: the middle estimate sits 1.7-fold (0.22 log units) below what was measured, within the range that was stated.
By their numbers in this assay, from the lowest: compounds 1, 2, 3 and 4 (each within the scatter of the next).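

Going by these compounds alone, this is the first change in the set made at a single place on an otherwise unchanged molecule, so it can be read on its own. In this assay, replacing (1-methylcyclopropyl)methyl with 1-methoxy-1-methylethyl gives a 2.0-fold higher number from compound 1 to compound 4 (0.30 log units; within the scatter). At this position, then, the three-membered ring can leave and a chain with an oxygen and one hydrogen-bond acceptor can enter, without a step beyond the usual scatter, although this step only just stays within it.

Going by these compounds, whether an amine or a carboxylic acid at this position would give a step beyond the scatter remains open. What lies behind the size of this step also remains open, as no measurement here speaks to it.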